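This account rests on a few compounds, and the source may have more. Where it says the series, first, only, none or still open, it means among the compounds named here.

Measured compounds:
Compound 1, `CC(C)OCCCNC(=O)c1csc(Nc2cc(Cl)c(Cl)c(Cl)c2)n1`, gives > 100000 nM in an ADME assay on MDCK cells (Canis lupus familiaris) for cytotoxicity, with a stated time of 48 h; on this read-out lower numbers stand for higher toxicity in this test and higher numbers for lower toxicity in this test; this is a limit of the assay, not a number.
Compound 2, `CCOCCCNC(=O)c1csc(Nc2cc(Cl)c(Cl)c(Cl)c2)n1`, gives > 100000 nM in this assay; again a limit.
Compound 3, `Cc1cc(Nc2nc(C(=O)NCCCOC(C)C)cs2)cc(C)c1Cl`, gives > 100000 nM in this assay; again a limit.

Compound 1 and compound 2 share one core and differ in a single place: hydrogen in place of methyl on a saturated chain carbon bound to an oxygen on a saturated carbon and a saturated chain carbon. The step that the two limits leave unreadable from compound 1 to compound 2 cannot be sized, because both values sit at the limit of > 100000 nM in this assay, at which 3 of the 3 values shown sit. Compound 3 carries a different core; the difference between the two cores is not broken down here. Compound 4, `CCOCCCNC(=O)c1csc(Nc2cc(C)c(Cl)c(C)c2)n1`, is not yet measured and differs from compound 3 by hydrogen in place of methyl on a saturated chain carbon bound to an oxygen on a saturated carbon and a saturated chain carbon, the same change as between compound 1 and compound 2, at the same place.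

For compound 4 the estimate in this assay is 100000 nM, expected between 50000 nM and 300000 nM. This expectation rests on compound 3 and on (the limit of > 100000 nM in this assay, at which 3 of the 3 values shown sit), where all three measured values sit. The expected step is a number no higher from compound 3 to compound 4 (the limit leaves the size open), estimated to stand beside a step that the two limits leave unreadable from compound 1 to compound 2 as another step that the limit would leave unreadable.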

Compound 4, half-maximal cytotoxic concentration: > 100000 nM
Compound 4: no number, only a limit; the forecaster's own chance of this, stated with the estimate: 85%; the middle value sits exactly at the limit.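

In this assay compound 4 gives > 100000 nM and this is a limit of the assay, not a number. No step can be read between compound 3 and compound 4, because both values sit at the same limit: the limit of > 100000 nM in this assay, at which 4 of the 4 values shown sit. The compounds shown leave open how far any of them lies from that limit, and whether the change from isopropoxy to ethoxy alters the half-maximal cytotoxic concentration at all.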